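The source may hold more compounds than are shown below. What is called first, only, known or untested is meant among the compounds shown, and "the series" means these compounds.

Compounds measured so far in a functional assay on MGC-803 cells (Homo sapiens) for inhibition, read by MTT assay, with a stated time of 72 h; a lower number here means a stronger inhibitor, a higher number a weaker inhibitor:
compound 1 `CC(C)c1ccc(-c2nc(SCc3cn(CC(=O)NC(=O)Nc4ccccn4)nn3)nc(Nc3ccc(F)cc3)c2C#N)cc1` — 17500 nM
compound 2 `CC(C)c1ccc(-c2nc(SCc3cn(CC(=O)NC(=O)Nc4ccccn4)nn3)nc(Nc3cccc([N+](=O)[O-])c3)c2C#N)cc1` — > 64000 nM
compound 3 `CC(C)c1ccc(-c2nc(SCc3cn(CC(=O)NC(=O)Nc4ccccn4)nn3)nc(Nc3ccccc3F)c2C#N)cc1` — > 64000 nM

Compound 3 gives only a limit in this assay, > 64000 nM, and not a number. Compound 2 likewise reaches only a limit, > 64000 nM. Compound 1 is the one member of the set with a number, 17500 nM, so compound 3 stands at the weak end of what is shown, together with compound 2; the limit of > 64000 nM in this assay, at which 2 of the 3 values shown sit, marks where both sit. The two readable steps both start from compound 1: an at least 3.6-fold higher number from compound 1 to compound 2 (0.56 log units; beyond the scatter) and an at least 3.6-fold higher number from compound 1 to compound 3 (0.56 log units; beyond the scatter). The step between compound 2 and compound 3 is a step that the two limits leave unreadable from compound 2 to compound 3.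

Compound 4 `CC(C)c1ccc(-c2nc(SCc3cn(CC(=O)NC(=O)Nc4ccccn4)nn3)nc(Nc3ccccc3)c2C#N)cc1` is not yet measured. Its change from compound 3 is hydrogen in place of fluoro on an aromatic carbon, on an aromatic carbon of a six-membered aromatic ring of carbon only. Going by the values given here, only the step from compound 1 to compound 3 touches the same phenyl, and it carried a fluoro from one carbon to another rather than removing it, so no measured step reads directly onto this change. Starting from a limit, the step is expected to be an at least 1.6-fold lower number from compound 3 to compound 4 (0.20 log units; that floor lies within the scatter), and compound 4 is expected to give about 40000 nM in this assay, between 12000 nM and 100000 nM.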

Compound 4, half-maximal inhibitory concentration: 15800 nM
For compound 4 the middle estimate is 2.5-fold (0.40 log units) above the measured one, within the range that was stated.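

Replacing the fluoro of the 2-fluorophenyl with hydrogen produces an at least 4.0-fold lower number from compound 3 to compound 4 (0.60 log units; beyond the scatter), and replacing the nitro with hydrogen produces an at least 4.0-fold lower number from compound 2 to compound 4 (0.60 log units; beyond the scatter). Removing the fluoro of compound 1 makes no readable difference, giving a 1.1-fold lower number from compound 1 to compound 4 (0.04 log units; within the scatter). The earlier compounds shown here could not separate a gain from the fluoro in compound 1 from a loss in compound 2 and compound 3; compound 4 places the loss with the fluoro of compound 3 and the nitro of compound 2, and shows that the plain phenyl needs no substituent to reach the level of compound 1 in this assay.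

Going by these compounds, compound 2 and compound 3 remain at a limit of the assay, so the full size of each loss stays unknown: the limit of > 64000 nM in this assay, at which 2 of the 4 values shown sit. How a methoxy group or an amine on this phenyl would read in this assay also stays open.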